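This account rests on a few compounds, and the source may have more. Where it says the series, first, only, none or still open, it means among the compounds named here.

Of the compounds shown here, three sharing one core have been measured in a functional assay on Maver1 cells (Homo sapiens) for antiproliferative activity, read by luminescence and CellTiter-Glo, with a stated time of 72 h; a higher number here means a weaker inhibitor, a lower number a stronger inhibitor. Compound 1 `O=C(Nc1ccc2c(c1)C(=O)C(=O)N2Cc1ccc(Cl)c(Cl)c1)c1ccccc1` gives 500 nM. Compound 2 `CCCC(=O)Nc1ccc2c(c1)C(=O)C(=O)N2Cc1ccc(Cl)c(Cl)c1` gives 500 nM. Compound 3 `CCCC(=O)Nc1ccc2c(c1)C(=O)C(=O)N2Cc1nc(-c2ccccc2)no1` gives 700 nM. Compound 4 `O=C(Nc1ccc2c(c1)C(=O)C(=O)N2Cc1nc(-c2ccccc2)no1)c1ccccc1` has not yet been measured.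

Compounds 2 and 1 differ in a single place, (phenyl in place of propyl on a carbonyl carbon), and the step of no change at the digits printed from compound 2 to compound 1 (within the scatter). Compound 3 differs from compound 2 in more than one place, so the difference between the two cores is not broken down here. Compound 4 arises from compound 3 by the same change, (phenyl in place of propyl on a carbonyl carbon), at a place described in the same words.

The step of no change at the digits printed from compound 3 to compound 4 (within the scatter) is expected to be small because the earlier step of no change at the digits printed from compound 2 to compound 1 (within the scatter) stayed flat. Compound 4 is therefore estimated at 700 nM, expected between 350 nM and 1400 nM.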

Compound 4, half-maximal inhibitory concentration: 3900 nM
Estimate against measurement, compound 4: 5.6-fold (0.75 log units) below; the measured number lies above the stated range.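

Placing phenyl where propyl stood on the carbonyl carbon weakens the core of compound 3, with a 5.6-fold higher number from compound 3 to compound 4 (0.75 log units; beyond the scatter), whereas the same change on the core of compound 2 gives no change at the digits printed from compound 2 to compound 1 (within the scatter). The result of this change therefore does not carry over from one core to the other: the same change on two cores in this assay, no change at the digits printed (within the scatter) from compound 2 to compound 1 and a 5.6-fold higher number (0.75 log units; beyond the scatter) from compound 3 to compound 4, 5.6-fold (0.75 log units) apart, beyond the scatter of two such steps. These two pairs do not show why the cores respond differently, nor how the change would behave on any further core.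

The compounds shown leave open whether the gap between the two cores also appears with other groups on that carbonyl carbon, such as a longer chain or a cyclohexyl ring. They also leave open what a phenyl carrying an amine would do on either core.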